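The source may report more compounds than this note shows. Statements on the series, on what has been measured and on what is new or still open speak of the compounds shown alone.

In an assay on isolated protein for inhibition of cathepsin S (Homo sapiens) (a lower number here means a stronger inhibitor, a higher number a weaker inhibitor), compound 2 `COc1cccc(C(=O)N[C@@H](CCC2CCCCC2)C(=O)NCCN2CCc3cc(F)ccc32)c1` gives 2130 nM, the highest number of the three measured compounds. Compound 1 `Cc1cccc(C(=O)N[C@@H](CC(C)C)C(=O)NCCNc2ccc(Cl)cc2)c1` gives 458 nM, and compound 3 `COc1cccc(C(=O)N[C@@H](CC(C)(C)C)C(=O)N[C@@H](CCS(C)(=O)=O)CN2CCc3cc(F)ccc32)c1` gives 14 nM, the lowest of the three. Compound 4 `CCOC(=O)C[C@@H](CN1CCc2cc(F)ccc21)NC(=O)[C@H](CCC1CCCCC1)NC(=O)c1cccc(OC)c1` has not yet been measured in this assay. It differs from compound 2 by (ethoxycarbonyl)methyl in place of hydrogen on a saturated chain carbon bound to an amide-type nitrogen and a saturated chain carbon. For the measured compounds named here, no measured pair shows this single change on its own, so the expectation rests on the wider picture: compound 3 gives 14 nM while compound 2 gives 2130 nM. A move toward a lower number is expected, with a step of a 7.1-fold lower number from compound 2 to compound 4 (0.85 log units; beyond the scatter). Compound 4 is therefore estimated at 300 nM, in a range from 60 nM to 1500 nM.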

Compound 4, inhibition constant: 16 nM
Estimate against measurement, compound 4: 19-fold (1.27 log units) above; the measured number lies below the stated range.
By their numbers in this assay, from the lowest: compounds 3 and 4 (each within the scatter of the next); then compound 1; then compound 2.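

In this assay, (ethoxycarbonyl)methyl in place of hydrogen on a saturated chain carbon bound to an amide-type nitrogen and a saturated chain carbon gives a 130-fold lower number from compound 2 to compound 4 (2.12 log units; beyond the scatter) with the rest of compound 2 unchanged. For the compounds shown here, this is the first single-place change that can be read here, and it shows that this carbon accepts substitution and that this one change alone moves the number well beyond the scatter. Nothing available explains the size of this step. Still open, going by these compounds, is whether a carboxylic acid, an amine or a plain methyl group on this carbon would give a similar step.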